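The compounds below may be only part of what the source reports. "The series", "measured", "known", "first", "only" and "open" are said of these compounds alone.

Measured in an assay on isolated protein for inhibition of Aromatase (Homo sapiens), read by fluorescence and colorimetric assay, with a stated time of 30 min; a higher number here means a weaker inhibitor, a lower number a stronger inhibitor:
compound 1 `CCCCCCCCCCc1cn(C(c2ccc(C#N)cc2)c2ccc(C#N)cc2)nn1`: 16000 nM
compound 2 `COc1ccc(OCc2cn(C(c3ccc(C#N)cc3)c3ccc(C#N)cc3)nn2)cc1`: 12200 nM
compound 3 `c1ccc(C(c2ccccc2)n2ccnn2)cc1`: 4580 nM

Compound 3 gives the lowest number of the three in this assay; compound 2 stands a step above it and compound 1 further still, both gaps beyond the scatter. Compound 3 also differs from compounds 1 and 2 in more than one place, so those gaps are not attributed to any single change.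

Compound 4 `CCCCCCc1cn(C(c2ccccc2)c2ccccc2)nn1` has not yet been measured. Against compound 3 the change is hexyl in place of hydrogen on an aromatic carbon.

Within the data shown here, the one measured single-place step, a 1.3-fold lower number from compound 1 to compound 2 (0.12 log units; within the scatter), swaps one large group for another on the same carbon of the core and is within the scatter; it does not test hydrogen against a chain. Compounds 1 and 2, which carry a chain on that carbon, give higher numbers than compound 3, but they carry nitrile groups too, so this only hints at direction. A modest rise is expected, a 1.7-fold higher number from compound 3 to compound 4 (0.24 log units; within the scatter), with wide uncertainty. Compound 4 is estimated at 8000 nM, in the range 2500 nM to 25000 nM.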

Compound 4, half-maximal inhibitory concentration: 14800 nM
Estimate against measurement, compound 4: 1.9-fold (0.27 log units) below; low and high end bracket the measured number.
By their numbers in this assay, from the lowest: compound 3; then compounds 2, 4 and 1 (each within the scatter of the next).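

In this assay, among these compounds, the step of a 3.2-fold higher number from compound 3 to compound 4 (0.51 log units; beyond the scatter) is the first direct test of hydrogen against a chain on this aromatic carbon, and it lies beyond the scatter, so the rise with hexyl is now measured rather than only hinted at. The earlier step of a 1.3-fold lower number from compound 1 to compound 2 (0.12 log units; within the scatter) only exchanged one large group for another on this carbon, so it could not show what a substituent there costs against hydrogen. No evidence is available that bears on the origin of this rise.

As far as these compounds go, whether a shorter chain such as methyl, or a chain ending in an amine or a carboxylic acid, would raise the number as much remains open. Also open, from the compounds shown here alone, is whether hexyl in place of hydrogen gives a similar step on the core carrying the two nitrile groups.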